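Methoxy addition on the hydrazone aryl ring in two cores

The source may hold more compounds than are shown below. What is called first, only, known or untested is meant among the compounds shown, and "the series" means these compounds.

Compound 1 `COc1ccc(/C=N/n2c(C)nc3c(cnn3S(=O)(=O)c3ccc(Cl)cc3)c2=O)cc1` and compound 2 `COc1ccc(/C=N/n2c(C)nc3c(cnn3S(=O)(=O)c3ccc(Cl)cc3)c2=O)cc1OC` share one core, and compound 3 `COc1ccc(/C=N/NC(=O)c2cn[nH]c2NC(C)=O)cc1` and compound 4 `COc1ccc(/C=N/NC(=O)c2cn[nH]c2NC(C)=O)cc1OC` share another. In a functional assay on MCF7 cells (Homo sapiens) for cytotoxicity, read by colorimetric assay and sulforhodamine B assay, with a stated time of 48 h (a lower number here means a stronger inhibitor, a higher number a weaker inhibitor), compound 1 gives 41900 nM. In this assay compound 2 gives 33600 nM, a step of a 1.2-fold lower number from compound 1 to compound 2 (0.10 log units; within the scatter), which is the change (methoxy in place of hydrogen on an aromatic carbon). In this assay compound 3 gives 61700 nM. The difference between the two cores is not broken down here. From compound 3 to compound 4 the same change is made, (methoxy in place of hydrogen on an aromatic carbon). Because the step of a 1.2-fold lower number from compound 1 to compound 2 (0.10 log units; within the scatter) in the first pair is within the scatter, the step from compound 3 to compound 4 is expected to be small as well, about a 1.2-fold lower number from compound 3 to compound 4 (0.07 log units; within the scatter) in this assay. For compound 4 the estimate in this assay is 52000 nM, with a range of 28000 nM to 95000 nM.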

Compound 4, half-maximal inhibitory concentration: 37100 nM
The estimate for compound 4 lay 1.4-fold (0.15 log units) above the measured number; measured number inside the range.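

In this assay, methoxy in place of hydrogen on an aromatic carbon gives a 1.7-fold lower number from compound 3 to compound 4 (0.22 log units; within the scatter). Set beside the step on the other core, the change carries across the two cores with no difference that can be told apart: the same change on two cores in this assay, a 1.2-fold lower number (0.10 log units; within the scatter) from compound 1 to compound 2 and a 1.7-fold lower number (0.22 log units; within the scatter) from compound 3 to compound 4, 1.3-fold (0.13 log units) apart, within the scatter of two such steps. Going by these compounds alone, this shows only that the step is small on both cores; it does not show that the methoxy moves the number on either core, and two pairs set no rule for the series.

Open, going by these compounds, is whether an amine, a carboxylic acid or a longer alkoxy chain at this place on the ring would give a step beyond the scatter. Also open, on these data alone, is whether the methoxy step stays this small on a third core.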